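The compounds below may be only part of what the source reports. "The series", "measured", "known", "first", "only" and "open" are said of these compounds alone.

Series notes. Compound 1 `CCCCCOc1nc(C(F)(F)F)ccc1CNC(=O)Nc1cccc2[nH]c(=O)ccc12` carries a pentyloxy group on the shared core; in an assay on HEK cells for antagonist activity at transient receptor potential cation channel subfamily V member 1 (Homo sapiens), read by FLIPR (a lower number here means a stronger inhibitor, a higher number a weaker inhibitor), compound 1 gives 2.72 nM. Compound 2 `CC1CCC(c2nc(C(F)(F)F)ccc2CNC(=O)Nc2cccc3[nH]c(=O)ccc23)CC1` carries 4-methylcyclohexyl at the same place; in this assay compound 2 gives 1.44 nM. Among the measured compounds shown here, the one measured step, a 1.9-fold lower number from compound 1 to compound 2 (0.28 log units; within the scatter), leaves compound 2 and compound 1 within the scatter of each other, so on the two numbers so far compound 2 stands apart from nothing.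

Compound 3 `O=C(NCc1ccc(C(F)(F)F)nc1-c1ccc(F)cc1)Nc1cccc2[nH]c(=O)ccc12` is the next change at this site: 4-fluorophenyl in place of 4-methylcyclohexyl on an aromatic carbon. For the measured compounds named here, the single step on record at this position swapped a chain for a saturated ring and stayed within the scatter; it bears on compound 3 only in showing that one exchange here produced no step beyond the scatter. Going by the values given here, an aromatic ring in place of the saturated one has no precedent, so no direction is indicated, and the expectation in this assay is no step beyond the scatter, a 2.1-fold higher number from compound 2 to compound 3 (0.32 log units; beyond the scatter). Compound 3 is therefore estimated at 3 nM, with a range from 1 nM to 10 nM.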

Compound 3, half-maximal inhibitory concentration: 1.93 nM
The estimate for compound 3 lay 1.6-fold (0.19 log units) above the measured number; the range from low to high includes it.
By their numbers in this assay, from the lowest: compounds 2, 3 and 1 (each within the scatter of the next).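

The step of a 1.3-fold higher number from compound 2 to compound 3 (0.13 log units; within the scatter) and the step of a 1.4-fold lower number from compound 1 to compound 3 (0.15 log units; within the scatter) in this assay show that a six-membered aromatic ring of carbon only, on this aromatic carbon next to the ring nitrogen, stays within the scatter of both the saturated ring and the pentyloxy chain. The site has now carried a chain, a saturated ring and an aromatic ring, and compounds 1, 2 and 3 all lie within the scatter of each other, so no exchange here yet separates one group from another. Nothing on hand gives a reason for this sameness.

Open, going by these compounds, is whether an amine or a carboxylic acid at this place would also stay within the scatter. Also open, on these data alone, is whether a methyl group, a longer chain or unsubstituted phenyl would do so.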